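The source may hold more compounds than are shown below. What is called first, only, known or untested is meant among the compounds shown, and "the series" means these compounds.

Compound 1 `O=S(=O)(NCCCNCc1ccc(Cl)c(C(F)(F)F)c1)c1cc(C(F)(F)F)cc(C(F)(F)F)c1` gives 7400 nM in a functional assay on MIA PaCa-2 cells (Homo sapiens) for inhibition, read by MTT assay, with a stated time of 72 h; a higher number here means a weaker inhibitor of growth, a lower number a stronger inhibitor of growth.
Compound 2 `O=S(=O)(NCCCCCCNCc1ccc(Br)cc1)c1c(Cl)cccc1Cl` gives 14700 nM in this assay.
Compound 3 `O=S(=O)(NCCCCCCNCc1ccc(Br)cc1)c1cc(C(F)(F)F)cc(C(F)(F)F)c1` gives 2970 nM in this assay.

Among these three numbers, compound 1 stands second highest. Its number and that of compound 2 lie within the scatter of each other, so the two cannot be told apart on these data. Compound 3 gives a number lower than that of compound 1 by a margin beyond the scatter, so on these numbers compound 3 inhibits growth more strongly than compound 1.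

Compound 4 `O=S(=O)(NCCCNCc1cccc(Cl)c1)c1cc(C(F)(F)F)cc(C(F)(F)F)c1` has not yet been measured in this assay. It differs from compound 1 in one place: 3-chlorophenyl in place of 4-chloro-3-(trifluoromethyl)phenyl on a saturated chain carbon bound to an amine nitrogen. Among the compounds with values here, no measured pair shows a change of this kind, so there is no step to lean on. The group that enters carries fewer heavy atoms than the group that leaves, and with so little to go on the expectation is a small step toward a higher number, one that may not clearly exceed the scatter. The step from compound 1 to compound 4 is expected to be a 1.6-fold higher number from compound 1 to compound 4 (0.21 log units; within the scatter). For compound 4 the estimate is 12000 nM, with a range from 4000 nM to 35000 nM.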

Compound 4, concentration for 50% growth inhibition: 4400 nM
For compound 4 the middle estimate is 2.7-fold (0.44 log units) above the measured one; the range from low to high includes it.
By their numbers in this assay, from the lowest: compounds 3, 4, 1 and 2 (each within the scatter of the next, the first and the last beyond it).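

Going from the 4-chloro-3-(trifluoromethyl)phenyl group to the 3-chlorophenyl group on a saturated chain carbon bound to an amine nitrogen gives a 1.7-fold lower number from compound 1 to compound 4 (0.23 log units; within the scatter) in this assay. Within the data shown here, this is the first comparison here between compounds that differ in only one place, and it shows that this position accepts a group with fewer heavy atoms with no readable change in growth inhibition. Nothing measured here explains this result.

A single step cannot show whether the chlorine on this ring contributes to growth inhibition, which a plain phenyl group at the same position would test. It also leaves open how the number would respond to a carboxylic acid or an amine on this ring.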